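Cyclohexyl for phenyl on the amide carbonyl: working notes

This account rests on a few compounds, and the source may have more. Where it says the series, first, only, none or still open, it means among the compounds named here.

Two compounds have been run in an assay on HEK293 cells for negative allosteric modulation of metabotropic glutamate receptor 5 (Homo sapiens), read by FLIPR; on this read-out higher numbers stand for weaker inhibition and lower numbers for stronger inhibition. Compound 1 `O=C(C1CCC(F)(F)CC1)N1CC(c2nc(-c3cccc(Cl)c3)no2)C1` reaches only the limit of the assay, returning > 10000 nM, which is a limit and not a number. Among the compounds with values here, compound 2 `Cc1cccc(-c2noc(C3CN(C(=O)c4cccc(F)c4)C3)n2)c1` gives 2100 nM in this assay, the only plain number in the set. Compound 3 `Cc1cccc(-c2noc(C3CN(C(=O)C4CCC(F)(F)CC4)C3)n2)c1` has not yet been measured. It differs from compound 2 in one place: 4,4-difluorocyclohexyl in place of 3-fluorophenyl on a carbonyl carbon. Within the data shown here, no pair of measured compounds differs in only one place, so no measured step is available to lean on. Compound 1 also carries a 4,4-difluorocyclohexyl group on a carbonyl carbon, and it sits at the limit (the limit of > 10000 nM in this assay, at which 1 of the 2 values shown sits). On that basis the step from compound 2 to compound 3 is expected to be a 3.8-fold higher number from compound 2 to compound 3 (0.58 log units; beyond the scatter), a loss beyond the scatter. Compound 3 is therefore estimated at 8000 nM, expected to fall between 3000 nM and 20000 nM, with a real chance that only a limit is returned.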

Compound 3, half-maximal inhibitory concentration: > 10000 nM
Compound 3 ended at the assay's limit; the forecaster's own chance of this, stated with the estimate: 45%; at least 1.2-fold (0.09 log units) between middle value and limit.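

In this assay, within the data shown here, the first readable step at this position is a loss: 4,4-difluorocyclohexyl in place of 3-fluorophenyl on the carbonyl carbon gives an at least 4.7-fold higher number from compound 2 to compound 3 (0.67 log units; beyond the scatter). On these data alone, compound 3 stands at a limit, > 10000 nM, which is not a number, so the full size of this loss is unknown. The step between compound 1 and compound 3, methyl in place of chloro on an aromatic carbon, cannot be read, as neither compound has a plain number: the limit of > 10000 nM in this assay, at which 2 of the 3 values shown sit.

As far as these compounds go, it remains open whether the loss follows from giving up the aromatic ring or from the two fluorines of the incoming group. A plain cyclohexyl or a pyridyl group on the same carbonyl carbon would help separate these two readings.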